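Trading a pyridazine for a methylpyridine on the ether side chain

This account rests on a few compounds, and the source may have more. Where it says the series, first, only, none or still open, it means among the compounds named here.

Three measured compounds share a core carrying a carboxylic acid chain and an ether substituent, and they are compared in an assay for inhibition of kynurenine 3-monooxygenase (Homo sapiens), read by mass spectrometry, with a stated time of 1 h; a lower number here means a stronger inhibitor, a higher number a weaker inhibitor. Compound 1 `O=C(O)CCn1c(=O)oc2cc(OCC3CCC3)c(Cl)cc21` gives 25.1 nM, and compound 2 `O=C(O)CCn1c(=O)oc2cc(OCc3ccccc3)c(Cl)cc21` gives 25.1 nM, so no change at the digits printed from compound 1 to compound 2 (within the scatter). Compound 3 `C[C@@H](Oc1cc2oc(=O)n(CCC(=O)O)c2cc1Cl)c1cccnn1` gives 1.26 nM, the lowest number of the three; the steps of a 20-fold lower number from compound 1 to compound 3 (1.30 log units; beyond the scatter) and a 20-fold lower number from compound 2 to compound 3 (1.30 log units; beyond the scatter) show that the ring with two nitrogens brought a large gain over both a saturated ring and a plain phenyl.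

Compound 4 `Cc1cccc([C@@H](C)Oc2cc3oc(=O)n(CCC(=O)O)c3cc2Cl)n1` has not been measured. It differs from compound 3 by 6-methylpyridin-2-yl in place of pyridazin-3-yl on a saturated chain carbon bound to an oxygen on an aromatic ring and a saturated chain carbon. Among the compounds with values here, no measured step covers exactly this swap. The steps into compound 3 show that an aromatic ring containing nitrogen works well here, and compound 4 keeps one ring nitrogen while adding a methyl, so a strong inhibitor is still expected, though the loss of one nitrogen leaves room for a modest weakening. The expected step is a 2.0-fold higher number from compound 3 to compound 4 (0.30 log units; within the scatter), a small change that may not exceed the scatter. Compound 4 is therefore estimated at 2.5 nM in this assay, with a range from 0.6 nM to 10 nM.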

Compound 4, half-maximal inhibitory concentration: 5.01 nM
For compound 4 the middle estimate is 2.0-fold (0.30 log units) below the measured one; low and high end bracket the measured number.
By their numbers in this assay, from the lowest: compound 3; then compound 4; then compounds 1 and 2 (each within the scatter of the next).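

At this position, on a saturated chain carbon bound to an oxygen on an aromatic ring and a saturated chain carbon, one nitrogen-containing aromatic ring cannot simply stand in for another: in this assay the swap from pyridazin-3-yl to 6-methylpyridin-2-yl gives a 4.0-fold higher number from compound 3 to compound 4 (0.60 log units; beyond the scatter). Part of the advantage over the earlier side chains survives, however, since compound 4 at 5.01 nM still has a lower number than compound 1 at 25.1 nM, so the large gain seen earlier does not depend entirely on having two ring nitrogens. No supporting measurement is available to explain why the number rises with this swap.

The swap removes one ring nitrogen and adds a methyl in a single move, so the compounds shown cannot say how much of the step belongs to each change. An unsubstituted pyridin-2-yl or a 6-methylpyridazin-3-yl on the same carbon would separate the two changes, since each differs from compound 3 or compound 4 by only the nitrogen or only the methyl.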